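Swapping Bromo for Fluoro on a Weakly Active Core

This account rests on a few compounds, and the source may have more. Where it says the series, first, only, none or still open, it means among the compounds named here.

Compound 1 `Cn1c(/C=C2/C(=O)Nc3ccc([N+](=O)[O-])cc32)nc2ccccc21` and compound 2 `Cn1c(/C=C2/C(=O)Nc3ccc(Br)cc32)nc2ccccc21` share one core and differ in a single ring substituent. In a functional assay on PC-3 cells (Homo sapiens) for cytotoxicity, read by MTT assay, with a stated time of 48 h (a lower number here means a stronger inhibitor, a higher number a weaker inhibitor), compound 1 gives > 50000 nM, which is a limit of the assay rather than a number. In this assay compound 2 likewise gives > 50000 nM, again a limit. The step that the two limits leave unreadable from compound 1 to compound 2 therefore cannot be read, as both values sit at the limit of > 50000 nM in this assay, at which 2 of the 2 values shown sit. Compound 2 thus stands at the limit, with no measured number placing it anywhere within the range that this assay can resolve.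

Compound 3 `Cn1c(/C=C2/C(=O)Nc3ccc(F)cc32)nc2ccccc21` differs from compound 2 in one place: fluoro in place of bromo on an aromatic carbon. Among the measured compounds shown here, only one measured step exists on this core, and it is the unreadable one, so nothing measured indicates how exchanging one halogen for another moves potency here. For the measured compounds named here, with both measured compounds at the limit, no step of any size in this assay can be expected with confidence, and the most likely outcome for compound 3 is another limit. Compound 3 is therefore estimated at 50000 nM, between 20000 nM and 200000 nM. The step of a number no higher from compound 2 to compound 3 (the limit leaves the size open) is expected to amount to no resolved change.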

Compound 3, half-maximal inhibitory concentration: 34300 nM
Estimate against measurement, compound 3: 1.5-fold (0.16 log units) above; low and high end bracket the measured number.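

In this assay, among the compounds shown here, compound 3 gives 34300 nM, the only true number on the shared core so far, so with fluoro on this aromatic carbon the assay yields a readable value rather than a limit. Fluoro in place of bromo gives an at least 1.4-fold lower number from compound 2 to compound 3 (0.16 log units; that floor lies within the scatter), and fluoro in place of nitro gives an at least 1.4-fold lower number from compound 1 to compound 3 (0.16 log units; that floor lies within the scatter). Each of these is only a floor, and since the floors lie within the scatter, a real gain in potency is not established, while the true size of either step stays open, as the other end of each is a limit: the limit of > 50000 nM in this assay, at which 2 of the 3 values shown sit.

The compounds shown leave open whether another group on this aromatic carbon, such as chloro, methoxy or an amine, would also give a readable value, and how that value would compare with the one for compound 3. They also leave open whether the fluoro result would hold if a longer chain replaced the methyl group on the shared core.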